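From E to Z: compound 3 to compound 4

This account rests on a few compounds, and the source may have more. Where it says the series, first, only, none or still open, it means among the compounds named here.

Compound 3 `COc1cc(/C=C/c2ccc3c(ccn3S(=O)(=O)c3ccccc3)c2)cc(OC)c1OC` gives > 5000 nM in a functional assay on A549 cells (Homo sapiens) for inhibition; a higher number here means a weaker inhibitor, a lower number a stronger inhibitor. That value is a limit of the assay and not a number, so its position in the series is only bounded. Compound 1 `COc1ccc(/C=C\c2ccc3ccccc3c2)cc1N` gives > 20000 nM in this assay, also a limit. Within the data shown here, compound 2 `COc1cc(/C=C\c2cn(C)c3ccccc23)cc(OC)c1OC` gives 3090 nM, the only true number so far.

Compound 4 `COc1cc(/C=C\c2ccc3c(ccn3S(=O)(=O)c3ccccc3)c2)cc(OC)c1OC` has the same atoms and bonds as compound 3. The change is the two compounds have the same atoms and bonds and differ only in configuration as drawn: 1 of 1 stereo elements differ; a double bond is drawn E in compound 3 and Z in compound 4: a double bond is drawn E in compound 3 and Z in compound 4.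

Among the measured compounds shown here, no measured pair isolates this change, so the expectation rests on indirect evidence. Compound 2, with its double bond drawn Z, reaches 3090 nM, which favours a numerical reading for compound 4. Compound 1 goes against this, since its double bond is also drawn Z and it gives only the limit of > 20000 nM. A moderate gain in inhibition is therefore expected, with a real chance of another limit. The expected step is an at least 3.3-fold lower number from compound 3 to compound 4 (0.52 log units; beyond the scatter), and it is only an estimate. For compound 4 the estimated value is 1500 nM, with an expected range of 200 nM to 8000 nM.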

Compound 4, half-maximal inhibitory concentration: > 5000 nM
Compound 4 ended at the assay's limit; the forecaster's own chance of this, stated with the estimate: 30%; middle value at least 3.3-fold (0.52 log units) from the limit.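

No step can be read from compound 3 to compound 4 in this assay, as both compounds sit at the same limit of the assay and neither value is a number: the limit of > 5000 nM in this assay, at which 2 of the 4 values shown sit.

On these data alone, whether the double bond drawn E or drawn Z gives the stronger inhibitor on this shared core stays open.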